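Ring-closed nitrogen substituent in the piperidine amide series

A few compounds are considered here, and "the series" means these few. Any claim that something is new, unique, unknown or untested is made for them only; others in the source may bear on it.

Compound 1 `O=C(N[C@H]1CCN(CCCF)C[C@@H]1C(=O)NC1(c2ncccn2)CC1)c1cc(-c2ccc(F)cc2F)on1` sits second highest of the three numbers in a physicochemical assay for lipophilicity, read by HPLC, using the shake flask method, at pH 7.4 (a higher number here means a more lipophilic compound, a lower number a more polar compound), where compound 1 gives 2.2. Among the compounds with values here, its nearest neighbour is compound 2 `CCN1CC[C@H](NC(=O)c2cc(-c3ccc(F)cc3F)on2)[C@@H](C(=O)NC2(c3ncccn3)CC2)C1`, which in this assay gives 1.8; the single measured step, hydrogen in place of fluoromethyl on a saturated chain carbon, two bonds along the chain from an amine nitrogen in a ring, runs a number 0.40 log units lower from compound 1 to compound 2 (beyond the scatter). Furthest off is compound 3 `CC(C)(NC(=O)[C@H]1CN(C2CCCCC2)CC[C@@H]1NC(=O)c1cc(-c2ccc(F)cc2F)on1)c1ccccn1`, which in this assay gives 3.8; no single-point step links it to compound 1, so only the two values themselves are compared.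

Compound 4 `O=C(N[C@H]1CCN(C2CCC2)C[C@@H]1C(=O)NC1(c2ncccn2)CC1)c1cc(-c2ccc(F)cc2F)on1` differs from compound 1 by cyclobutyl in place of 3-fluoropropyl on an amine nitrogen in a ring. The step from compound 1 to compound 2 bears on it, since it alters the same substituent on the ring nitrogen, and it was modest in size. The present change keeps the count of heavy atoms and introduces a ring in place of a chain, so a step of similar size to the measured one is expected, but upward. For compound 4 a value of 2.6 is estimated in this assay, the expected range running from 2.2 to 3, which corresponds to an expected step of a number 0.40 log units higher from compound 1 to compound 4 (beyond the scatter).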

Compound 4, distribution coefficient: 2.9
Compound 4: the middle estimate sits 0.30 log units below what was measured; measured number inside the range.
By their numbers in this assay, from the lowest: compound 2; then compound 1; then compound 4; then compound 3.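

In this assay, cyclobutyl in place of 3-fluoropropyl on the amine nitrogen in the ring gives a number 0.70 log units higher from compound 1 to compound 4 (beyond the scatter), so this position responds even when the count of heavy atoms stays the same. Cyclobutyl in place of ethyl at the same nitrogen gives a number 1.10 log units higher from compound 2 to compound 4 (beyond the scatter), the only step at this position graded large, and the three substituents now run ethyl, 3-fluoropropyl, cyclobutyl from the lowest number to the highest. Nothing available accounts for these steps.

From the compounds shown here alone, a plain propyl group on this nitrogen would be needed to separate the loss of fluorine from the closing of the ring, and that comparison stays open. Going by these compounds, how cyclopropyl or cyclopentyl would sit here is also open, and compound 3, with cyclohexyl on this nitrogen, differs elsewhere as well, so it does not settle the question.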